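This account rests on a few compounds, and the source may have more. Where it says the series, first, only, none or still open, it means among the compounds named here.

Of the compounds shown here, three built on a shared core have been tested in a functional assay on RAW264.7 cells (Mus musculus) for inhibition, read by Griess assay, with stated times of 3 h and 24 h; a higher number here means a weaker inhibitor, a lower number a stronger inhibitor. Compound 1 `C=C1CCC2C(C)(CO)[C@H](O)CC[C@@]2(C)[C@@H]1CCn1c(N)nccc1=O` gives > 100000 nM, which is a limit of the assay and not a number. Compound 3 `C=C1CCC2[C@](C)(CO)[C@H](O)CC[C@@]2(C)[C@@H]1CCOc1ccc2ccc(=O)oc2c1` gives > 50000 nM, which is also a limit and not a number. Among the measured compounds shown here, compound 2 `C=C1CCC2[C@](C)(CO)[C@H](O)CC[C@@]2(C)[C@@H]1CCOc1ccc(Oc2ccccc2)cc1` gives 12800 nM, the only true number among the three, so it is the one firm reference point available.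

Compound 4 `C=C1CCC2[C@](C)(CO)[C@H](O)CC[C@@]2(C)[C@@H]1CCOc1ccc(-c2cc(=O)c3cc(C)ccc3o2)cc1` comes from compound 2 through one change on an aromatic carbon of a six-membered aromatic ring of carbon only, para to a large group: a group of 12 heavy atoms (10 carbon, 2 oxygen; one six-membered aromatic ring of carbon only, one six-membered aromatic ring with 1 hetero atom) in place of a group of 7 heavy atoms (6 carbon, 1 oxygen; one six-membered aromatic ring of carbon only), on an aromatic carbon. The phenoxy group leaves, and a larger group with a six-membered aromatic ring with 1 hetero atom enters.

For the measured compounds named here, no two measured compounds differ in only one place, so the data give no direct size for a swap like this. No step beyond the usual scatter is expected in this assay, although the risk lies towards higher numbers. Going by the values given here, the one caution is compound 3, which also carries a six-membered aromatic ring with 1 hetero atom in its side group and reaches only > 50000 nM.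

The estimated outcome is a 1.4-fold higher number from compound 2 to compound 4 (0.15 log units; within the scatter). For compound 4 the expected value is 18000 nM, with an estimated range from 5000 nM to 60000 nM.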

Compound 4, half-maximal inhibitory concentration: > 100000 nM
Compound 4 ended at the assay's limit; the forecaster's own chance of this, stated with the estimate: 30%; at least 5.5-fold (0.74 log units) between middle value and limit.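

In this assay, the swap on this aromatic carbon, para to a large group, is not neutral: putting the larger group with its six-membered aromatic ring with 1 hetero atom in place of phenoxy gives an at least 7.8-fold higher number from compound 2 to compound 4 (0.89 log units; beyond the scatter). Compound 4 gives > 100000 nM, which is a limit of the assay and not a number, so the true size of the step cannot be read and only its lower end is known, because the measurement stops here: the limit of > 100000 nM in this assay, at which 2 of the 4 values shown sit. This is the first pair shown that differs in one place, and it shows that the firm reading of compound 2 depends on the group at this position and does not survive this particular change.

One step cannot separate the effect of the number of heavy atoms in the entering group from that of its ring with a hetero atom or its double bond outside aromatic rings. The compounds shown also leave open how a methoxy group or a plain phenyl ring on the same aromatic carbon would read, and whether any group there gives a lower number than phenoxy.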